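The compounds below may be only part of what the source reports. "The series", "measured", "known", "first", "only" and "open" are said of these compounds alone.

In a functional assay on SGC-7901 cells (Homo sapiens) for antiproliferative activity, read by MTT assay, with a stated time of 48 h (a higher number here means a weaker inhibitor, a lower number a stronger inhibitor), compound 3 `Clc1ccc(-c2nnc(SCc3ccc(Cl)nc3)o2)cc1` gives 8.62 ug/mL, the highest number of the three measured and so the weakest inhibitor among them. Compound 1 `Cc1ccc(-c2nnc(SCc3ccc(Cl)nc3)o2)cc1` gives 3.62 ug/mL and compound 2 `COc1ccc(-c2nnc(SCc3ccc(Cl)nc3)o2)cc1` gives 3.5 ug/mL. These two do not separate, with a step of a 1.0-fold lower number from compound 1 to compound 2 (0.01 log units; within the scatter).

Compound 4 `Nc1ccc(-c2nnc(SCc3ccc(Cl)nc3)o2)cc1` keeps the shared core and changes one group: amino in place of chloro on an aromatic carbon, para to a large group (amino in place of chloro on an aromatic carbon). Within the data shown here, the series holds no measured amino example, so the nearest evidence is the pair of steps that bring in chloro in place of methyl and methoxy: a 2.4-fold higher number from compound 1 to compound 3 (0.38 log units; beyond the scatter) and a 2.5-fold higher number from compound 2 to compound 3 (0.39 log units; beyond the scatter). Both are modest, beyond the scatter and run towards a higher number. Taken in reverse, they suggest that removing chloro may give a modest step towards a lower number in this assay. Three compounds cannot show that amino will track methyl or methoxy, so the range is kept wide and reaches back to the number of compound 3. The expected step is a 1.9-fold lower number from compound 3 to compound 4 (0.28 log units; within the scatter). The estimate for compound 4 is 4.5 ug/mL, with an expected range from 2 ug/mL to 10 ug/mL.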

Compound 4, half-maximal inhibitory concentration: 8.48 ug/mL
Beside the measured number, compound 4's estimate is 1.9-fold (0.28 log units) below it, within the range that was stated.
By their numbers in this assay, from the lowest: compounds 2 and 1 (each within the scatter of the next); then compounds 4 and 3 (each within the scatter of the next).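

In this assay, amino and chloro do not separate at this position, para to a large group: a 1.0-fold lower number from compound 3 to compound 4 (0.01 log units; within the scatter), even though a hydrogen-bond donor and acceptor enter with amino. Losing chloro therefore does not by itself bring the number down, and the shift seen earlier with methyl and methoxy does not extend to amino. The steps of a 2.4-fold higher number from compound 2 to compound 4 (0.38 log units; beyond the scatter) and a 2.3-fold higher number from compound 1 to compound 4 (0.37 log units; beyond the scatter) are both modest, so the four compounds form two pairs, with compounds 1 and 2 at the lower numbers and compounds 3 and 4 at the higher, and no measurement at hand accounts for this split.

Four substituents at one position are too few to show whether this two-level split is a general feature of the series or what, if anything, the members of each pair share. A hydroxy, a dimethylamino, a nitrile or a carboxylic acid at the same position would show whether other groups fall into one of the two pairs or give numbers outside the narrow span seen so far.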